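Nitro for chloro in two related dihydropyrimidine series

The source may hold more compounds than are shown below. What is called first, only, known or untested is meant among the compounds shown, and "the series" means these compounds.

Measured compounds:
compound 1 `CCOC(=O)C1=C(C)NC(=O)NC1c1cn(C(=O)CNc2ccc([N+](=O)[O-])cc2)c2ccccc12` — > 1000 ug/mL
compound 2 `CCOC(=O)C1=C(C)NC(=S)NC1c1cn(C(=O)CNc2ccc(Cl)cc2)c2ccccc12` — 80 ug/mL
compound 3 `CCOC(=O)C1=C(C)NC(=O)NC1c1cn(C(=O)CNc2ccc(Cl)cc2)c2ccccc12` — 200 ug/mL

Of the compounds shown here, three have been measured in a functional assay on MCF7 cells (Homo sapiens) for cytotoxicity, read by MTT assay, with a stated time of 72 h; a lower number here means a stronger inhibitor, a higher number a weaker inhibitor. Compound 2 `CCOC(=O)C1=C(C)NC(=S)NC1c1cn(C(=O)CNc2ccc(Cl)cc2)c2ccccc12` gives 80 ug/mL in this assay, the lowest of the two numbers read, with compound 3 `CCOC(=O)C1=C(C)NC(=O)NC1c1cn(C(=O)CNc2ccc(Cl)cc2)c2ccccc12` at 200 ug/mL as its nearest neighbour. For compound 1 `CCOC(=O)C1=C(C)NC(=O)NC1c1cn(C(=O)CNc2ccc([N+](=O)[O-])cc2)c2ccccc12` the assay reports only a limit, > 1000 ug/mL. The difference between the cores of compound 2 and compound 3 is not broken down here.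

Compound 1 differs from compound 3 by nitro in place of chloro on an aromatic carbon. That change brings an at least 5.0-fold higher number from compound 3 to compound 1 (0.69 log units; beyond the scatter), a step whose size can only be bounded because of the limit of > 1000 ug/mL in this assay, at which 1 of the 3 values shown sits.

Compound 4 `CCOC(=O)C1=C(C)NC(=S)NC1c1cn(C(=O)CNc2ccc([N+](=O)[O-])cc2)c2ccccc12`, not yet measured, stands to compound 2 as compound 1 stands to compound 3: it differs by nitro in place of chloro on an aromatic carbon, the same kind of change on the same place. Resting on the step seen in compound 3 and compound 1, an at least 5.0-fold higher number from compound 3 to compound 1 (0.69 log units; beyond the scatter), a weakening of similar direction is expected from compound 2 to compound 4 in this assay, with the step estimated as a 5.0-fold higher number from compound 2 to compound 4 (0.70 log units; beyond the scatter). Compound 4 is therefore expected to give about 400 ug/mL, likely between 150 ug/mL and 1200 ug/mL, with a real chance that only a limit is reported.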

Compound 4, half-maximal inhibitory concentration in the MCF7 assay: > 1000 ug/mL
Compound 4: only a limit was reported; the forecaster's own chance of this, stated with the estimate: 35%; at least 2.5-fold (0.39 log units) between middle value and limit.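

In the MCF7 assay, nitro in place of chloro pushes the number the same way on both cores, with an at least 12-fold higher number from compound 2 to compound 4 (1.09 log units; beyond the scatter), so the direction of the change carries from one core to the other, while its size on each core cannot be compared: the same change on two cores in the MCF7 assay, an at least 5.0-fold higher number (0.69 log units; beyond the scatter) from compound 3 to compound 1 and an at least 12-fold higher number (1.09 log units; beyond the scatter) from compound 2 to compound 4; the limit leaves it open whether they differ In the MCF7 assay compound 4 gives > 1000 ug/mL, which is a limit and not a number, and it is not the only such result: the limit of > 1000 ug/mL in the MCF7 assay, at which 2 of the 4 values shown sit. In a physicochemical assay for lipophilicity (on this read-out higher numbers stand for higher lipophilicity and lower numbers for lower lipophilicity), compound 2 gives 3.44 and compound 4 gives 2.88, so the pair also separates, but nothing here shows whether that shift has any link to the weaker result of compound 4: the measured partition coefficient of compound 2, 3.44, and of compound 4, 2.88, a number 0.56 log units lower (beyond the scatter)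

The compounds shown leave open whether the loss belongs to nitro itself or would follow other replacements of chloro, as only these two groups appear at that place; a fluorine atom, a methoxy group or an amine on the same aromatic carbon would begin to separate those readings. Also open, going by these compounds, is how large the step truly is on either core, which would take a nitro compound that gives a measured number rather than a limit.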